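The source may report more compounds than this note shows. Statements on the series, on what has been measured and on what is new or still open speak of the compounds shown alone.

Compound 1 `Cc1ccccc1-c1nn(-c2ccc(OC(F)(F)F)cc2)cc1CNCCN1CCN(C)CC1` has a cytotoxicity reading in an ADME assay on Huh-7 cells (Homo sapiens) for cytotoxicity (a lower number here means that less compound is tolerated, a higher number that more compound is tolerated), where compound 1 gives 17000 nM. A second compound, compound 2 `Cc1ccccc1-c1nn(-c2ccc(F)cc2F)cc1CNCc1ccncc1`, belongs to the same set. In this assay compound 2 reaches only a limit of the assay, > 20000 nM, rather than a number. For the measured compounds named here, compound 1 thus holds the only numerical value here; the other entry is the limit of > 20000 nM in this assay, at which 1 of the 2 values shown sits. Going by the values given here, no two measured compounds differ in a single place, so no measured step is available to guide expectations.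

Compound 3 `Cc1ccccc1-c1nn(-c2cccc(C(F)(F)F)c2)cc1CNCCN1CCN(C)CC1` has not yet been measured in this assay. Compared with compound 1, compound 3 carries 3-(trifluoromethyl)phenyl in place of 4-(trifluoromethoxy)phenyl on an aromatic nitrogen. With nothing measured to lean on, the change is expected to move the reading by no more than the usual scatter, in either direction. The expected step is a 1.1-fold lower number from compound 1 to compound 3 (0.05 log units; within the scatter). Compound 3 is expected to give about 15000 nM, within a range from 7000 nM to 30000 nM.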

Compound 3, half-maximal cytotoxic concentration: 18000 nM
The estimate for compound 3 lay 1.2-fold (0.08 log units) below the measured number; the range from low to high includes it.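

For the compounds shown here, this is the first measured step at the aromatic nitrogen of the shared core. In this assay, putting 3-(trifluoromethyl)phenyl in place of 4-(trifluoromethoxy)phenyl gives a 1.1-fold higher number from compound 1 to compound 3 (0.02 log units; within the scatter), so although the entering group lacks the oxygen of the leaving group, the two compounds cannot be told apart. Nothing measured here gives a reason for this result.

Only these two fluorine-bearing phenyl groups can be compared at this position, both alongside the same ((2-(4-methylpiperazin-1-yl)ethyl)amino)methyl group, so one step cannot describe other groups there. As far as these compounds go, whether a phenyl ring bearing a carboxylic acid or an amine would give a different reading stays open, as does the effect of changing that side chain on compounds carrying these two phenyl groups.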